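This account rests on a few compounds, and the source may have more. Where it says the series, first, only, none or still open, it means among the compounds named here.

Measured so far in an ADME assay on Vero cells (Chlorocebus sabaeus) for cytotoxicity; on this read-out lower numbers stand for higher toxicity in this test and higher numbers for lower toxicity in this test:
- compound 1 `CCCCNc1[nH]c2c(F)cc(F)cc2c(=O)c1C(C)=O`: > 25000 nM
- compound 2 `CC(=O)c1c(NCc2ccc(F)cc2F)[nH]c2c(F)cc(F)cc2c1=O`: > 25000 nM
- compound 3 `CC(=O)c1c(NCc2ccc(F)cc2)[nH]c2c(F)cc(F)cc2c1=O`: > 25000 nM

Compound 3 stands at > 25000 nM, which is a limit of this assay and not a number. Going by the values given here, the series as a whole offers only (the limit of > 25000 nM in this assay, at which 3 of the 3 values shown sit), and no compound measured so far goes against this.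

Compound 4 `COc1ccc(CNc2[nH]c3c(F)cc(F)cc3c(=O)c2C(C)=O)cc1` differs from compound 3 by one change: methoxy in place of fluoro on an aromatic carbon. In words, this is methoxy in place of fluoro on an aromatic carbon, para to a large group.

The closest measured change is a step that the two limits leave unreadable from compound 2 to compound 3, hydrogen in place of fluoro on an aromatic carbon. The wider changes, a step that the two limits leave unreadable from compound 1 to compound 2 and a step that the two limits leave unreadable from compound 1 to compound 3, also have no readable size. None of these steps gives a direction, yet none of the three compounds left the limit, so no change beyond the scatter is expected in this assay.

The expected change is a step that the limit leaves unreadable from compound 3 to compound 4.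

For compound 4 the estimate is 30000 nM, with an expected range from 15000 nM to 60000 nM.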

Compound 4, half-maximal cytotoxic concentration: > 25000 nM
Compound 4 ended at the assay's limit; the forecaster's own chance of this, stated with the estimate: 85%; the middle value is on the limit's open side.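

Going by these compounds alone, no step to compound 4 from compound 1, compound 2 or compound 3 can be read in this assay, as all four compounds sit at one limit of the assay: the limit of > 25000 nM in this assay, at which 4 of the 4 values shown sit.
The compounds shown leave open whether any of these groups changes toxicity in this assay, as none has given a number.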